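Swapping Trifluoromethoxy for Trifluoromethyl on a Weak Compound

This account rests on a few compounds, and the source may have more. Where it says the series, first, only, none or still open, it means among the compounds named here.

In a functional assay on MCF7 cells (Homo sapiens) for antiproliferative activity, with a stated time of 96 h (a higher number here means a weaker inhibitor, a lower number a stronger inhibitor), compound 1 `Cc1cc(=O)oc2cc(OCC(=O)c3ccc(C(C)(C)C)cc3)ccc12` gives 20700 nM. Compound 2 `Cc1cc(=O)oc2cc(OCC(=O)c3ccc(OC(F)(F)F)cc3)ccc12` reaches only a limit of the assay, > 100000 nM. Compound 3 `Cc1cc(=O)oc2cc(OCC(=O)c3ccc(C(F)(F)F)cc3)ccc12` has trifluoromethyl in place of trifluoromethoxy on an aromatic carbon. Going by the values given here, the only measured step that bears on this, an at least 4.8-fold higher number from compound 1 to compound 2 (0.68 log units; beyond the scatter), put trifluoromethoxy in place of tert-butyl on an aromatic carbon. It shows that this position can matter, but it does not test the new swap, and both groups here carry fluorine. The expected change is small, an at least 1.2-fold lower number from compound 2 to compound 3 (0.09 log units; that floor lies within the scatter), with none expected beyond the scatter. For compound 3 the estimate is 80000 nM, with an expected range of 30000 nM to 200000 nM.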

Compound 3, half-maximal inhibitory concentration: > 100000 nM
Compound 3: no number, only a limit; the forecaster's own chance of this, stated with the estimate: 50%; middle value at least 1.2-fold (0.09 log units) away from the limit.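

Compound 3 gives an at least 4.8-fold higher number from compound 1 to compound 3 (0.68 log units; beyond the scatter) in this assay, with trifluoromethyl in place of tert-butyl. Trifluoromethoxy is therefore not the only group at this position to fall short of tert-butyl, since a second fluorine-bearing group does so too. The step from compound 2 to compound 3 cannot be read, because neither compound gives a number: the limit of > 100000 nM in this assay, at which 2 of the 3 values shown sit.

The compounds shown leave open whether trifluoromethyl and trifluoromethoxy differ at all. They also leave open whether an amine, a carboxylic acid or a longer chain in this place would match compound 1 or fall short of it.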